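The source may report more compounds than this note shows. Statements on the series, on what has been measured and on what is new or still open speak of the compounds shown alone.

In a functional assay on MCF7 cells (Homo sapiens) for cytotoxicity, read by sulforhodamine B assay (on this read-out lower numbers stand for stronger inhibition of growth and higher numbers for weaker inhibition of growth), three compounds sharing one core have been read so far. Compound 1 `CC1=CC[C@@H]([C@@](C)(O)CCCC(C)(C)NC(=S)N/N=C\c2ccc(C)cc2)CC1` gives > 100000 nM, which is a limit of the assay and not a number. Compound 2 `CC1=CC[C@@H]([C@@](C)(O)CCCC(C)(C)NC(=S)N/N=C\c2ccc(N(C)C)cc2)CC1` gives > 100000 nM, again a limit. Among the compounds with values here, compound 3 `CC1=CC[C@@H]([C@@](C)(O)CCCC(C)(C)NC(=S)N/N=C\c2cccc([N+](=O)[O-])c2)CC1` gives 18300 nM, the only true number in the set, so it stands as the one compound with a measured growth-inhibiting concentration.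

Compound 4 `CC1=CC[C@@H]([C@@](C)(O)CCCC(C)(C)NC(=S)N/N=C\c2ccc([N+](=O)[O-])cc2)CC1` has 4-nitrophenyl in place of 3-nitrophenyl on a carbon with a double bond to nitrogen, the same atoms joined differently (4-nitrophenyl in place of 3-nitrophenyl on a carbon with a double bond to nitrogen).

Within the data shown here, no measured step moves the nitro group alone. The nearest evidence is an at least 5.4-fold lower number from compound 1 to compound 3 (0.73 log units; beyond the scatter) and an at least 5.4-fold lower number from compound 2 to compound 3 (0.73 log units; beyond the scatter), and each of these swaps the whole aryl group, so neither separates the group from where it sits. The remaining step, a step that the two limits leave unreadable from compound 1 to compound 2, adds nothing on size. Compound 4 keeps the nitro group of compound 3, which reads 18300 nM, yet its name shares the 4- pattern of the 4-methylphenyl in compound 1 and the 4-(dimethylamino)phenyl in compound 2, so a drift upward seems possible.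

The expected result is a 1.5-fold higher number from compound 3 to compound 4 (0.18 log units; within the scatter), probably no step beyond the scatter, and if anything towards a higher number. For compound 4 the estimated value is 28000 nM, with an expected range of 9000 nM to 100000 nM.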

Compound 4, concentration for total growth inhibition: > 100000 nM
Compound 4: no number, only a limit; the forecaster's own chance of this, stated with the estimate: 25%; at least 3.5-fold (0.55 log units) between middle value and limit.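

Moving the nitro group, with the same atoms joined differently, is the first change here that separates a group from where it sits: in this assay there is an at least 5.4-fold higher number from compound 3 to compound 4 (0.73 log units; beyond the scatter). The nitro group alone is therefore not enough for a readable growth-inhibiting concentration in this set, since the 4-nitrophenyl of compound 4 does not keep what the 3-nitrophenyl of compound 3 gives, and the earlier swaps of the whole aryl group could not show this. The steps from compound 1 and compound 2 to compound 4 cannot be read, and these three compounds cannot be ordered among themselves, because all of them rest on one limit: the limit of > 100000 nM in this assay, at which 3 of the 4 values shown sit.

With compound 3 as the only compound that gives a true number, the shown set cannot say how far activity could rise or fall around the 3-nitrophenyl group. It also leaves open whether a nitrile or a carboxylic acid in place of the nitro group of compound 3 would keep a readable value or fall back to the limit.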